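Trifluoromethyl in place of methyl on compound 2

The source may report more compounds than this note shows. Statements on the series, on what has been measured and on what is new or still open speak of the compounds shown alone.

compound 1 `O=C(c1ccc2nc(NC(=O)C(F)(F)F)cn2c1)c1ccc(C(F)(F)F)cc1F`: 100%
compound 2 `Cc1ccc(F)c(C(=O)c2ccc3nc(NC(=O)C(F)(F)F)cn3c2)c1`: 71.7%
compound 3 `Cc1ccc(C(=O)c2ccc3nc(NC(=O)C(F)(F)F)cn3c2)cc1F`: 81.5%

In a functional assay on SK-LU-1 cells (Homo sapiens) for inhibition, read by sulforhodamine B assay, with a stated time of 48 h, tested at 50 uM (a higher number here means more inhibition of growth at the concentration tested, a lower number less inhibition of growth), compound 2 gives 71.7%, within the scatter of compound 3 and beyond the scatter from compound 1. Compound 4 `O=C(c1ccc2nc(NC(=O)C(F)(F)F)cn2c1)c1cc(C(F)(F)F)ccc1F` differs from compound 2 as follows: trifluoromethyl in place of methyl on an aromatic carbon. Among the compounds with values here, the only measured single change is a number 9.8 percentage points higher from compound 2 to compound 3 (within the scatter), which does not exchange methyl for trifluoromethyl and so bears on this change only weakly. Within the data shown here, compound 1 is the one measured compound carrying trifluoromethyl, and at 100% it supports expecting a moderate rise in this assay, on thin evidence. The expected step is a number 14.3 percentage points higher from compound 2 to compound 4 (beyond the scatter). The estimate for compound 4 is 86%, with an expected range of 68% to 100%.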

Compound 4, percent growth inhibition at one concentration: 70.5%
Compound 4: the middle estimate sits 15.5 percentage points above what was measured; the range from low to high includes it.
By their numbers in this assay, from the lowest: compounds 4, 2 and 3 (each within the scatter of the next, the first and the last beyond it); then compound 1.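

In this assay, trifluoromethyl in place of methyl on this aromatic carbon, meta to a large group and para to a fluoro group, gives a number 1.2 percentage points lower from compound 2 to compound 4 (within the scatter) and so no separable difference. At this place, then, the larger fluorinated group and methyl cannot be told apart by this read-out, and carrying trifluoromethyl does not in itself go with a higher number. Nothing measured here accounts for this outcome.

From the compounds shown here alone, whether a methoxy group or an amine on this carbon would read differently from methyl remains open. Also open, going by these compounds, is whether the result holds when the fluoro group is replaced by hydrogen.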